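Chloro in Place of Methoxy: Expected Cytotoxicity of Compound 4

The source may report more compounds than this note shows. Statements on the series, on what has been measured and on what is new or still open speak of the compounds shown alone.

Compound 1, `COc1ccc(NC(=O)Nc2cc(C)nc3ccccc23)cc1`, was examined in an ADME assay on HEK293 cells (Homo sapiens) for cytotoxicity, with a stated time of 72 h; on this read-out lower numbers stand for an effect already at smaller amounts and higher numbers for an effect only at larger amounts of compound. In this assay compound 1 gives > 25000 nM, which is a limit of the assay and not a number. Compound 2, `COc1ccc(NC(=O)Nc2cc(C)nc3ccccc23)cc1F`, carries fluoro in place of hydrogen on an aromatic carbon, and in this assay compound 2 gives > 25000 nM, again a limit. The step that the two limits leave unreadable from compound 1 to compound 2 therefore cannot be read. Among the compounds with values here, compound 3, `COC(=O)c1cccc(NC(=O)Nc2cc(C)nc3ccccc23)c1`, is the one member with a number: in this assay compound 3 gives 26000 nM. Within the data shown here, compound 1 thus stands at the limit, shared with one other compound (the limit of > 25000 nM in this assay, at which 2 of the 3 values shown sit), and the single numerical value lies close to that limit. Compound 4, `Cc1cc(NC(=O)Nc2ccc(Cl)cc2)c2ccccc2n1`, differs from compound 1 by chloro in place of methoxy on an aromatic carbon. Among the measured compounds shown here, no measured step bears on chloro in place of methoxy; the only measured step is unreadable, and all values shown sit at or near the limit. The expected step is therefore a step that the limit leaves unreadable from compound 1 to compound 4, none beyond the scatter. For compound 4 the estimate in this assay is 30000 nM, expected between 15000 nM and 60000 nM, most probably reported again only as a limit.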

Compound 4, half-maximal effective concentration: > 25000 nM
Compound 4 ended at the assay's limit; the forecaster's own chance of this, stated with the estimate: 70%; the middle value lies beyond the limit too.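

Compound 1 and compound 4 each stand only at a limit in this assay, so no new step can be read between them: the limit of > 25000 nM in this assay, at which 3 of the 4 values shown sit.

The compounds shown leave open how large any effect of chloro in place of methoxy on cytotoxicity is.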